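The source may hold more compounds than are shown below. What is called first, only, known or untested is meant among the compounds shown, and "the series" means these compounds.

Of the compounds shown here, three sharing one core have been measured in a functional assay on KB cells (Homo sapiens) for cytotoxicity, read by spectrophotometry and crystal violet staining; on this read-out lower numbers stand for stronger inhibition and higher numbers for weaker inhibition. Compound 1, `N#Cc1c(Cl)n(C2O[C@H](CO)[C@@H](O)[C@H]2O)c2cc(Cl)c(Cl)cc12`, gives 35000 nM. Compound 2, `N#Cc1c(Cl)n(C2O[C@H](CN=[N+]=[N-])[C@@H](O)[C@H]2O)c2cc(Cl)c(Cl)cc12`, gives 60000 nM. Compound 3, `O=Cc1c(Cl)n(C2O[C@H](CF)[C@@H](O)[C@H]2O)c2cc(Cl)c(Cl)cc12`, gives 20000 nM, the lowest of the three numbers; its gap to compound 1 is within the scatter, while compound 2 stands beyond it.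

Compound 4, `[N-]=[N+]=NC[C@H]1OC(n2c(Cl)c(C=O)c3cc(Cl)c(Cl)cc32)[C@H](O)[C@@H]1O`, has not yet been measured. It differs from compound 3 in one place: azido in place of fluoro on a saturated chain carbon bound to a saturated ring carbon. Among the compounds with values here, only one measured step bears on this: a 1.7-fold higher number from compound 1 to compound 2 (0.23 log units; within the scatter), where azido entered at the same place, though there it replaced hydroxy rather than fluoro. That step stayed within the scatter. Within the data shown here, the data hold no step in which fluoro at this position is exchanged for another group, so the one related step is the only guide.

On that basis compound 4 is expected to land close to compound 3, with any shift in this assay staying within the usual scatter, if anything leaning toward a slightly higher number as seen for compound 2 against compound 1. Compound 4 is therefore estimated at 30000 nM, within 12000 nM to 80000 nM, meaning a step of a 1.5-fold higher number from compound 3 to compound 4 (0.18 log units; within the scatter).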

Compound 4, half-maximal inhibitory concentration: 25000 nM
Estimate against measurement, compound 4: 1.2-fold (0.08 log units) above; measured number inside the range.
By their numbers in this assay, from the lowest: compounds 3, 4, 1 and 2 (each within the scatter of the next, the first and the last beyond it).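

In this assay, within the data shown here, the step of a 1.3-fold higher number from compound 3 to compound 4 (0.10 log units; within the scatter) is the first direct reading of azido against fluoro on a saturated chain carbon bound to a saturated ring carbon, and it stays within the scatter. Together with a 1.7-fold higher number from compound 1 to compound 2 (0.23 log units; within the scatter) it shows azido entering this place twice, against hydroxy with cyano on the aromatic carbon and against fluoro with formyl there, and neither exchange moves the number beyond the scatter. Among these compounds, the new compound also gives the first one-place reading of the aromatic carbon, where a 2.4-fold lower number from compound 2 to compound 4 (0.38 log units; beyond the scatter) is a modest step beyond the scatter and the only such step among those that can be read here, though nothing available explains either result.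

From the compounds shown here alone, whether the formyl for cyano step holds with hydroxy or fluoro on the chain stays open, as it is read here only with azido in that place. Going by these compounds, how an amine or a longer chain would read on this saturated chain carbon, or a carboxylic acid in place of formyl on the aromatic carbon, also stays open.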